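The source may report more compounds than this note shows. Statements on the series, on what has been measured and on what is new or still open speak of the compounds shown alone.

Measured compounds:
Compound 1, `O=C(CCN1CCN(c2ccnc3cc(Cl)ccc23)CC1)N/N=C/c1ccc(Cl)cc1` — 200 nM
Compound 2, `CC(C)Oc1ccc(/C=N/NC(=O)CCN2CCN(c3ccnc4cc(Cl)ccc34)CC2)cc1` — 3600 nM
Compound 3, `O=C(CCN1CCN(c2ccnc3cc(Cl)ccc23)CC1)N/N=C/c1ccc([N+](=O)[O-])cc1` — 12100 nM

In an ADME assay on cells (Splenocyte, Mus musculus, strain BALB/c) for cytotoxicity, read by thymidine incorporation, with a stated time of 24 h (a higher number here means a weaker inhibitor, a lower number a stronger inhibitor), compound 1 gives the lowest of the three numbers, so among these compounds it is the strongest inhibitor, with compound 2 the nearest and compound 3 the furthest away. Compound 4, `COc1cc(/C=N/NC(=O)CCN2CCN(c3ccnc4cc(Cl)ccc34)CC2)ccc1OC(C)C`, has not yet been tested in this assay. It differs from compound 1 in one place: 4-isopropoxy-3-methoxyphenyl in place of 4-chlorophenyl on a carbon with a double bond to nitrogen.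

Going by the values given here, one measured step bears directly on part of this change. Putting isopropoxy in place of chloro on an aromatic carbon gave an 18-fold higher number from compound 1 to compound 2 (1.26 log units; beyond the scatter), a large step toward weaker inhibition. Among the compounds with values here, the further addition of a methoxy group has no measured counterpart here, so its effect is unknown. The step of a 61-fold higher number from compound 1 to compound 3 (1.78 log units; beyond the scatter) shows that another replacement of the chloro also weakened inhibition, and a 3.4-fold higher number from compound 2 to compound 3 (0.53 log units; beyond the scatter) shows that the alternatives to chloro themselves differ.

Compound 4 is therefore expected to be a clearly weaker inhibitor than compound 1, with the step of a 25-fold higher number from compound 1 to compound 4 (1.40 log units; beyond the scatter) estimated to resemble the step to compound 2 in direction and size. For compound 4 the estimated value in this assay is 5000 nM, in the range 1500 nM to 20000 nM.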

Compound 4, half-maximal inhibitory concentration: 8800 nM
Beside the measured number, compound 4's estimate is 1.8-fold (0.25 log units) below it, within the range that was stated.
By their numbers in this assay, from the lowest: compound 1; then compound 2; then compounds 4 and 3 (each within the scatter of the next).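

In this assay, methoxy in place of hydrogen on an aromatic carbon is the only change of its kind among these compounds, and it gives a modest further rise (a 2.4-fold higher number from compound 2 to compound 4 (0.39 log units; beyond the scatter)), so adding this group to the isopropoxy compound recovers none of the ground lost on leaving chloro. Taken whole, 4-isopropoxy-3-methoxyphenyl in place of 4-chlorophenyl on a carbon with a double bond to nitrogen is a large step (a 44-fold higher number from compound 1 to compound 4 (1.64 log units; beyond the scatter)), which leaves compound 1 alone at the low end, with all three replacements of its 4-chlorophenyl giving clearly higher numbers. The comparison with 4-nitrophenyl (a 1.4-fold lower number from compound 3 to compound 4 (0.14 log units; within the scatter)) lies within the scatter, so this assay does not separate these two groups even though they share no substituent.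

Whether the low number of compound 1 belongs to chloro in particular stays open, since a 4-bromophenyl, a 4-fluorophenyl or a ring bearing an amine or a carboxylic acid does not appear among the compounds shown, and methoxy appears only together with isopropoxy. Nothing given here accounts for the size of any of these steps.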